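Naphthyl ether to chloromethylphenyl ether in a thiosemicarbazone series

The compounds below may be only part of what the source reports. "The series", "measured", "known", "first", "only" and "open" are said of these compounds alone.

Compound 1: `S=C(N/N=C/c1ccc(Oc2ccccc2)cc1)Nc1ccc(Br)cc1`, 6.38
Compound 2: `S=C(N/N=C/c1ccc(Oc2ccc3ccccc3c2)cc1)Nc1ccc(Br)cc1`, 6.93

Among the compounds with values here, in a physicochemical assay for lipophilicity, in phosphate buffer, measured as octanol-water partition, with a stated time of 24 h (a lower number here means a more polar compound, a higher number a more lipophilic compound), compound 2 stands highest of the two measured compounds; its nearest neighbour is compound 1, and the single step, a number 0.55 log units higher from compound 1 to compound 2 (beyond the scatter), lies beyond the scatter. Compound 3, `Cc1cc(Oc2ccc(/C=N/NC(=S)Nc3ccc(Br)cc3)cc2)ccc1Cl`, is not yet measured. It differs from compound 2 in one place: 4-chloro-3-methylphenyl in place of naphthalen-2-yl on an oxygen on an aromatic ring. Within the data shown here, only one measured step bears on this change, the one from compound 1 to compound 2, and it ran upward by a modest amount when naphthalen-2-yl replaced phenyl. The group entering compound 3 is smaller than naphthalen-2-yl by the counted atoms but carries a chlorine and a methyl, so no step beyond the scatter is expected in either direction; the expected step is a number 0.07 log units higher from compound 2 to compound 3 (within the scatter). Compound 3 is therefore estimated at 7, with a range from 6.6 to 7.5.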

Compound 3, partition coefficient: 7.89
For compound 3 the middle estimate is 0.89 log units below the measured one; measured number outside the range, above it.
By their numbers in this assay, from the lowest: compound 1; then compound 2; then compound 3.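

In this assay this position on the oxygen carried a far larger change than the earlier pair showed: 4-chloro-3-methylphenyl in place of naphthalen-2-yl gave a number 0.96 log units higher from compound 2 to compound 3 (beyond the scatter) with fewer heavy atoms entering than leaving. The same group in place of phenyl gave a number 1.51 log units higher from compound 1 to compound 3 (beyond the scatter) and so put compounds 1 and 3, each with a single aromatic ring at this place, at the two ends of the series, with the two-ring compound 2 going against any order by ring count. Nothing measured here explains this result.

The compounds shown leave open whether the chlorine or the methyl accounts for the step, as neither appears alone on the phenyl ring. They also leave open how this position would read with a polar group such as an amine or a carboxylic acid.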